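The compounds below may be only part of what the source reports. "The series", "measured", "known", "first", "only" and "open" are said of these compounds alone.

Measured in a functional assay on HCT-116 cells (Homo sapiens) for inhibition, read by colorimetric assay, with a stated time of 3 days; a lower number here means a stronger inhibitor, a higher number a weaker inhibitor:
- Compound 1 `COc1ccc(OC)c(NC(=O)CCCCCCNC(=O)C(O)(O)C(F)(F)F)c1`: 3870 nM
- Compound 2 `O=C(CCCCCCNC(=O)C(O)(O)C(F)(F)F)Nc1nc2ccccc2o1`: 3450 nM
- Compound 3 `COc1ccccc1NC(=O)CCCCCCNC(=O)C(O)(O)C(F)(F)F`: 10100 nM

Compound 3 gives the highest of these three numbers, which makes it the weakest inhibitor of the set in this assay. Its steps to both other compounds lie beyond the scatter.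

The next compound, compound 4 `O=C(CCCCCCNC(=O)C(O)(O)C(F)(F)F)Nc1nc2ccccc2s1`, carries 1,3-benzothiazol-2-yl in place of 2-methoxyphenyl on an amide-type nitrogen. Among the measured compounds shown here, no compound with 1,3-benzothiazol-2-yl has been measured yet, so the expectation rests on two neighbouring steps. The closer one is a 2.9-fold higher number from compound 2 to compound 3 (0.47 log units; beyond the scatter), where 2-methoxyphenyl replaces 1,3-benzoxazol-2-yl at the same place. The change to compound 4 runs the opposite way, from 2-methoxyphenyl back to a group of similar name. The other is a 2.6-fold higher number from compound 1 to compound 3 (0.42 log units; beyond the scatter), with hydrogen in place of methoxy on an aromatic carbon, and it shows a modest shift of similar size within the 2-methoxyphenyl series.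

On the evidence of compound 2, with its 3450 nM, a modest step towards a lower number is expected. The estimate amounts to an expected 2.7-fold lower number from compound 3 to compound 4 (0.42 log units; beyond the scatter). For compound 4 the estimated value is 3800 nM, with an expected range from 1600 nM to 9000 nM.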

Compound 4, half-maximal inhibitory concentration: 2370 nM
The estimate for compound 4 lay 1.6-fold (0.21 log units) above the measured number; the measured number falls inside the stated range.
By their numbers in this assay, from the lowest: compounds 4, 2 and 1 (each within the scatter of the next); then compound 3.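

In this assay, 1,3-benzothiazol-2-yl on the amide-type nitrogen gives a 4.3-fold lower number from compound 3 to compound 4 (0.63 log units; beyond the scatter), so a second group with a five-membered aromatic ring bearing hetero atoms joins the 1,3-benzoxazol-2-yl of compound 2 on the lower side of compound 3, although compound 1, with only a six-membered aromatic ring of carbon, also gives 3870 nM. The exchange of 1,3-benzoxazol-2-yl for 1,3-benzothiazol-2-yl gives a 1.5-fold lower number from compound 2 to compound 4 (0.16 log units; within the scatter), which lies within the scatter, so this assay does not tell these two groups apart at this position. Nothing available here accounts for either step.

From the compounds shown here alone, it remains open whether a methoxy group or an amine on the six-membered ring of 1,3-benzothiazol-2-yl would leave the number where it stands, and whether a plain phenyl or a pyridine ring on the same nitrogen would fall nearer to compound 3 or to compound 4. The compounds shown also share one chain and one end group, so the effect of a longer chain, or of a carboxylic acid at that end, on these steps is unknown.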